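Trimming the amide side chain back toward a bare amine

The source may report more compounds than this note shows. Statements on the series, on what has been measured and on what is new or still open speak of the compounds shown alone.

Compounds measured so far:
- compound 1, `N[C@@H]1CCc2ccccc2N(Cc2ccc(-c3ccccc3-c3nn[nH]n3)cc2)C1=O`: 9 uM
- compound 2, `CC(C)(CC(=O)N[C@@H]1CCc2ccccc2N(Cc2ccc(-c3ccccc3-c3nn[nH]n3)cc2)C1=O)NCc1ccccc1`: 65 uM
- compound 3, `CC(C)(CC(=O)N[C@@H]1CCc2ccccc2N(Cc2ccc(-c3ccccc3-c3nn[nH]n3)cc2)C1=O)NCCO`: 30 uM

All three share one core and differ only in what sits on the amine nitrogen of that core. In a functional assay on cells (Pituitary gland cell) with growth hormone secretagogue receptor type 1 (Rattus norvegicus) as the target (a lower number here means that less compound is needed, a higher number that more compound is needed for the effect), compound 3 stands second highest of the three numbers, so it needs more compound than compound 1 and less than compound 2. The step of a 3.3-fold higher number from compound 1 to compound 3 (0.52 log units; beyond the scatter) shows that attaching the whole (2-((2-hydroxyethyl)amino)-2-methylpropyl)carbonyl group to the amine of compound 1 raised the number, while a 2.2-fold lower number from compound 2 to compound 3 (0.34 log units; beyond the scatter) shows that swapping phenyl for hydroxymethyl at the end of that chain lowered it.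

Compound 4, `CC(C)(N)C(=O)N[C@@H]1CCc2ccccc2N(Cc2ccc(-c3ccccc3-c3nn[nH]n3)cc2)C1=O`, carries a much shorter side chain: 1-amino-1-methylethyl in place of 2-((2-hydroxyethyl)amino)-2-methylpropyl on a carbonyl carbon. This cuts the chain back to a point between compound 1 and compound 3 in size, and both measured steps bear on it. The one that removed the chain entirely lowered the number; the one that altered its tail moved it only modestly. A modest drop is therefore expected in this assay, roughly a 3.0-fold lower number from compound 3 to compound 4 (0.48 log units; beyond the scatter), landing near compound 1 without clearly passing it.

The estimate for compound 4 in this assay is 10 uM, with a likely range from 3 uM to 30 uM.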

Compound 4, concentration for half-maximal effect: 0.03 uM
Compound 4: middle estimate off by 330-fold (2.52 log units), on the high side, outside the stated range (below it).
By their numbers in this assay, from the lowest: compound 4; then compound 1; then compound 3; then compound 2.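

In this assay, within the data shown here, the group on this carbonyl carbon turns out to control the result far more strongly than the earlier compounds suggested: the short 1-amino-1-methylethyl group gives a large gain over both longer chains (a 1000-fold lower number from compound 3 to compound 4 (3.00 log units; beyond the scatter); a 2200-fold lower number from compound 2 to compound 4 (3.34 log units; beyond the scatter)). The earlier compounds shown here showed only modest differences, and both acylated compounds stood above the bare amine, yet compound 4 reverses that order (a 300-fold lower number from compound 1 to compound 4 (2.48 log units; beyond the scatter)), so placing a carbonyl group on this amine does not in itself raise the number, and the outcome depends on what that carbonyl carries. No measurement shown here accounts for this large gain.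

Compound 4 differs from compound 3 in both chain length and the substituent on the side-chain nitrogen, so the effects of these two changes cannot be separated; the 2-amino-2-methylpropyl group, with an unsubstituted amine on the longer chain, would help to separate them. As far as these compounds go, it also remains open whether the methyl groups and the amine of the short chain are each needed, as aminomethyl or hydroxymethyl at the same place would show.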